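The source may hold more compounds than are shown below. What is called first, only, known or untested is meant among the compounds shown, and "the series" means these compounds.

In a functional assay on MCF7 cells (Homo sapiens) for antiproliferative activity, read by sulforhodamine B assay, with a stated time of 48 h (on this read-out higher numbers stand for weaker inhibition and lower numbers for stronger inhibition), compound 2 `O=C1NCCN1c1ccc(S(=O)(=O)Nc2cccc(Oc3ccccc3)c2)cc1` gives 220 nM, the lower of the two numbers recorded so far. Its neighbour, compound 1 `Cc1ccccc1NS(=O)(=O)c1ccc(N2CCNC2=O)cc1`, gives 280 nM in this assay, and the gap between the two lies within the scatter of repeated measurements, so the two stand side by side. Compound 3 `COc1cccc(NS(=O)(=O)c2ccc(N3CCNC3=O)cc2)c1` has not yet been measured; it differs from compound 2 by methyl in place of phenyl on an oxygen on an aromatic ring. Going by the values given here, no step between two measured compounds is available to weigh this change, so the expected step of a 1.8-fold higher number from compound 2 to compound 3 (0.26 log units; within the scatter) is small, if anything toward a weaker number. Compound 3 is estimated at 400 nM, within 150 nM to 1100 nM.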

Compound 3, half-maximal inhibitory concentration: 120 nM
The estimate for compound 3 lay 3.3-fold (0.52 log units) above the measured number; measured number below the stated range.
By their numbers in this assay, from the lowest: compounds 3, 2 and 1 (each within the scatter of the next, the first and the last beyond it).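

In this assay, methoxy in place of phenoxy gives a 1.8-fold lower number from compound 2 to compound 3 (0.26 log units; within the scatter) and so shows that the number holds at this level without the phenyl on that oxygen. Going by these compounds alone, the change of 3-methoxyphenyl in place of 2-methylphenyl on the sulfonamide nitrogen gives a 2.3-fold lower number from compound 1 to compound 3 (0.37 log units; beyond the scatter) and is the only modest step here that is beyond the scatter. Nothing given here explains either step. From the compounds shown here alone, whether a longer chain than methyl on that oxygen would keep this number remains open, as does the effect of an amine or a carboxylic acid at this place on the aromatic ring.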